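Methyl on the phenolic oxygen: urea pair against amide pair

A few compounds are considered here, and "the series" means these few. Any claim that something is new, unique, unknown or untested is made for them only; others in the source may bear on it.

Measured compounds:
Compound 1 `O=C(Nc1cccc(-n2cc(-c3ccncc3)c(-c3cc(O)cc(Cl)c3)n2)c1)Nc1ccc(Cl)c(Cl)c1` gives -41.3% in a functional assay on UO-31 cells (Homo sapiens) for inhibition, read by sulforhodamine B assay, with a stated time of 48 h, tested at 10 uM; on this read-out lower numbers stand for a stronger effect and higher numbers for a weaker effect at the one concentration tested.
Compound 2 `COc1cc(Cl)cc(-c2nn(-c3cccc(NC(=O)Nc4ccc(Cl)c(Cl)c4)c3)cc2-c2ccncc2)c1` gives 0.64% in this assay.
Compound 3 `O=C(Nc1cccc(-n2cc(-c3ccncc3)c(-c3cc(O)cc(Cl)c3)n2)c1)c1cc(C(F)(F)F)cc(C(F)(F)F)c1` gives 49.2% in this assay.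

Compound 1 and compound 2 share one core and differ only by methyl in place of hydrogen on an oxygen on an aromatic ring. That single change moves the read-out by a number 41.9 percentage points higher from compound 1 to compound 2 (beyond the scatter), so the methylated compound 2 sits far to the weaker side of compound 1 in this assay.

Compound 3 carries a different core; the difference between the core of compound 1 and the core of compound 3 is not broken down here. Compound 3 stands highest of the three, with compound 2 nearest and compound 1 furthest, both gaps beyond the scatter.

Compound 4 `COc1cc(Cl)cc(-c2nn(-c3cccc(NC(=O)c4cc(C(F)(F)F)cc(C(F)(F)F)c4)c3)cc2-c2ccncc2)c1` is the methylated counterpart of compound 3, differing from it by methyl in place of hydrogen on an oxygen on an aromatic ring. Among the compounds with values here, the place of the change is the same in both pairs, so this is the same change as the one from compound 1 to compound 2.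

If the change behaves on the core of compound 3 as it did on the core of compound 1, compound 4 is expected to move by about a number 30.8 percentage points higher from compound 3 to compound 4 (beyond the scatter) in this assay. This expectation rests on compound 3 at 49.2% and on the step of a number 41.9 percentage points higher from compound 1 to compound 2 (beyond the scatter). Compound 4 is therefore estimated at 80%, most likely between 55% and 105%.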

Compound 4, a percentage reported as activity, at one concentration (the size of the read-out at that concentration, not a potency): 54.3%
Beside the measured number, compound 4's estimate is 25.7 percentage points above it, outside the stated range (below it).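

On the core of compound 3, the hydroxy to methoxy change in this assay gives a number 5.1 percentage points higher from compound 3 to compound 4 (within the scatter), so compound 3 at 49.2% and compound 4 at 54.3% cannot be told apart on this read-out. The large step seen on the core of compound 1 therefore does not carry over in size to the core of compound 3, and the effect of this methyl in the series has to be read core by core: the same change on two cores in this assay, a number 41.9 percentage points higher (beyond the scatter) from compound 1 to compound 2 and a number 5.1 percentage points higher (within the scatter) from compound 3 to compound 4, 36.8 percentage points apart, beyond the scatter of two such steps

These two pairs show only that the size of the step can depend on the core; they do not show which part of the core sets it, and they offer no rule for a third core.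

The compounds shown leave open whether the gap between the two steps follows the urea or amide link or the aryl group carried on that link, as neither link appears here with the aryl group of the other. Also open, from the compounds shown here alone, is how the same oxygen reads with an ethyl group or a longer chain in place of the methyl, and how either core reads with an amine in place of the hydroxy.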